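Changing the benzyl group at a solubility limit

The source may report more compounds than this note shows. Statements on the series, on what has been measured and on what is new or still open speak of the compounds shown alone.

Compound 1 (`O=C(O)c1ccc(C(=O)/C(=C\c2ccc(Cl)c([N+](=O)[O-])c2)SCc2ccc(Br)cc2)cc1`) stands on a limit alone. In a physicochemical assay for solubility (a higher number here means a more soluble compound, a lower number a less soluble compound), compound 1 gives < 1000 ug/mL as a limit of the assay and not as a number. In this assay compound 2 (`O=C(O)c1ccc(C(=O)/C(=C\c2ccc(Br)c([N+](=O)[O-])c2)SCc2ccc(Br)cc2)cc1`) gives < 1000 ug/mL as a limit too. Neither compound has a number: what stands is the limit of < 1000 ug/mL in this assay, at which 2 of the 2 values shown sit, and nothing firmer.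

Compound 3 (`O=C(O)c1ccc(C(=O)/C(=C\c2ccc(Cl)c([N+](=O)[O-])c2)SCc2ccc(Cl)cc2Cl)cc1`) departs from compound 1 at one place (2,4-dichlorophenyl in place of 4-bromophenyl on a saturated chain carbon bound to a sulfur), with 2,4-dichlorophenyl in place of 4-bromophenyl on a saturated chain carbon bound to a sulfur. Among the measured compounds shown here, only one measured step exists (a step that the two limits leave unreadable from compound 1 to compound 2), and it is of little help: it has no readable size, and it concerns bromo in place of chloro on an aromatic carbon, not this group. No size or direction therefore carries over to this assay from it, and the expected change is only a loose estimate (a step that the limit leaves unreadable from compound 1 to compound 3). Compound 3 is expected at 300 ug/mL with an estimated range from 60 ug/mL to 1000 ug/mL and the assay may well report only a limit again.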

Compound 3, solubility: < 1000 ug/mL
Compound 3: a limit, no number (the forecaster's own chance of this, stated with the estimate: 85%); the middle value lies beyond the limit too.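

In this assay compound 3 gives < 1000 ug/mL, a limit of the assay and not a number, so no step can be read between compound 1 and compound 3. The compounds shown leave open how soluble each one actually is, and whether either change of group shifts solubility at all: the limit of < 1000 ug/mL in this assay, at which 3 of the 3 values shown sit.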